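A Larger Chain in Place of Propyl: Expected Potency

This account rests on a few compounds, and the source may have more. Where it says the series, first, only, none or still open, it means among the compounds named here.

Compound 1, `CCNc1nc(N)c2nc(O)n(Cc3ccccc3)c2n1`: 1 uM
Compound 2, `CCCc1nc(N)c2nc(O)n(Cc3ccccc3)c2n1`: 1 uM

Of the compounds shown here, two have been measured in a functional assay (spleen, spleen) for activation, with Mus musculus as the target; a lower number here means that less compound is needed, a higher number that more compound is needed for the effect. In this assay compound 1 gives 1 uM and compound 2 gives 1 uM. Going by the values given here, the single step between them, no change at the digits printed from compound 1 to compound 2 (within the scatter), shows that swapping the chain on this aromatic carbon left the read-out where it was. Compound 2 therefore stands level with compound 1.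

The next compound, compound 3, `CCCC[S+]([O-])c1nc(N)c2nc(O)n(Cc3ccccc3)c2n1`, again changes only that position: a group of 6 heavy atoms (4 carbon, 1 oxygen, 1 sulfur; no ring) in place of a group of 3 heavy atoms (3 carbon; no ring), on an aromatic carbon. Among the compounds with values here, no measured step involves this larger chain, so the only guidance is the step from compound 1 to compound 2, which stayed within the scatter. Compound 3 is expected to behave much like compound 2, with a step of no change at the digits printed from compound 2 to compound 3 (within the scatter), so its estimated value is 1 uM, within a range of 0.3 uM to 5 uM.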

Compound 3, minimum effective concentration: 0.01 uM
Compound 3: the middle estimate sits 100-fold (2.00 log units) above what was measured; the measured number lies below the stated range.
By their numbers in this assay, from the lowest: compound 3; then compounds 1 and 2 (each within the scatter of the next).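

In this assay, this position proves sensitive to what it carries: the group of 6 heavy atoms gives a 100-fold lower number from compound 2 to compound 3 (2.00 log units; beyond the scatter) and, set against the ethylamino compound, a 100-fold lower number from compound 1 to compound 3 (2.00 log units; beyond the scatter). Going by these compounds alone, the earlier pair exchanged only two groups of 3 heavy atoms, so its flat result said nothing about a larger chain containing oxygen and sulfur, which clearly reduces the amount of compound needed for the effect. Nothing available here explains this large drop.

The entering group differs from propyl in size and in its oxygen and sulfur atoms all at once, so these compounds cannot show which of those differences matters. On these data alone, whether a plain hexyl chain, or a butyl chain attached through sulfur alone without the oxygen, would give a similarly low number remains open.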